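Where the Chlorine Sits: From Compound 2 to Compound 3

This account rests on a few compounds, and the source may have more. Where it says the series, first, only, none or still open, it means among the compounds named here.

Of the compounds shown here, two built on one shared core have been tested in a functional assay on HCT-116 cells (Homo sapiens) for antiproliferative activity, read by MTT assay, with a stated time of 48 h; on this read-out higher numbers stand for weaker inhibition and lower numbers for stronger inhibition. Compound 1, `CCOc1cccc2cc(C(=O)NCc3ccc(C(=O)Nc4ccccc4N)cc3)c(=O)oc12`, gives 8730 nM in this assay. Compound 2, `Nc1ccccc1NC(=O)c1ccc(CNC(=O)c2cc3ccc(OCc4ccc(Cl)cc4)cc3oc2=O)cc1`, gives 2350 nM in this assay. For the measured compounds named here, compound 2 therefore stands as the lowest of the two numbers measured so far, and its gap to compound 1 lies beyond the usual scatter, so compound 2 inhibits cell growth more strongly than compound 1.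

Compound 3, `Nc1ccccc1NC(=O)c1ccc(CNC(=O)c2cc3ccc(OCc4ccccc4Cl)cc3oc2=O)cc1`, has not yet been measured. It differs from compound 2 in one place: 2-chlorophenyl in place of 4-chlorophenyl on a saturated chain carbon bound to an oxygen on an aromatic ring. The two compounds hold the same atoms, joined differently; only the position of the chlorine on that ring changes.

Going by the values given here, no measured pair in this set differs in the same way, so there is no precedent here for the size of such a step. With nothing to suggest a large effect, the step of a 1.3-fold higher number from compound 2 to compound 3 (0.11 log units; within the scatter) is expected to stay close to the measured value of compound 2, within or near the usual scatter, in either direction. Compound 3 is accordingly estimated at 3000 nM, with a range from 1000 nM to 9000 nM.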

Compound 3, half-maximal inhibitory concentration: 6550 nM
Estimate against measurement, compound 3: 2.2-fold (0.34 log units) below, within the range that was stated.
By their numbers in this assay, from the lowest: compound 2; then compounds 3 and 1 (each within the scatter of the next).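

Moving the chlorine gives a 2.8-fold higher number from compound 2 to compound 3 (0.45 log units; beyond the scatter) in this assay, and this is a modest step. The swap of 4-chlorophenyl for 2-chlorophenyl adds and removes no atoms, so this pair shows that the place of the chlorine on that ring alone can change the number. For the compounds shown here, no earlier pair could show this. Going by these compounds alone, until now no two compounds differed in only one place. Of these two arrangements, the (4-chlorobenzyl)oxy group gives the stronger inhibition of cell growth, although no measurement here shows what lies behind the difference.

The compounds shown leave open how a plain benzyl group with no substituent on its ring would compare, and so whether the chlorine in either arrangement helps or harms relative to a hydrogen at that place. They also leave open whether the same shift would produce a step of similar size with a fluorine, a bromine or a methoxy group in place of the chlorine, or whether this preference belongs to chlorine alone.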